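Bromo for methyl beside hydroxy in the amide series

A few compounds are considered here, and "the series" means these few. Any claim that something is new, unique, unknown or untested is made for them only; others in the source may bear on it.

Measured so far in a functional assay on KG-1 cells (Homo sapiens) for cytotoxicity, read by luminescence and CellTiter-Glo, with a stated time of 3 days; on this read-out lower numbers stand for stronger inhibition and higher numbers for weaker inhibition:
compound 1 `O=C(Nc1cc(C(F)(F)F)cc(C(F)(F)F)c1)c1cc(Br)ccc1O`, 300 nM
compound 2 `O=C(Nc1cc(C(F)(F)F)cc(C(F)(F)F)c1)c1cc(F)ccc1O`, 470 nM
compound 3 `Cc1cccc(C(=O)Nc2ccc(C#N)cc2)c1O`, 8980 nM

Compound 3 gives the highest number of the three. Its nearest neighbour is compound 2, whose value stands well below it, beyond the scatter, and compound 1 stands further below still, also beyond the scatter. For the measured compounds named here, compound 3 differs from the other two in the whole of both aromatic rings, so no single measured step connects it to them.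

The next compound, compound 4 `N#Cc1ccc(NC(=O)c2cccc(Br)c2O)cc1`, is reached from compound 3 by bromo in place of methyl on an aromatic carbon, the change sitting on an aromatic carbon of a six-membered aromatic ring of carbon only, ortho to the hydroxy group and meta to a large group. Going by the values given here, the one measured step, a 1.6-fold higher number from compound 1 to compound 2 (0.19 log units; within the scatter), is a halogen swap at a different place on that ring and stays within the scatter; it does not bear directly on a methyl-to-bromo exchange. Among the compounds with values here, no measured pair tests this exchange. In this assay the expected step is a 1.3-fold lower number from compound 3 to compound 4 (0.11 log units; within the scatter), which is no change beyond the scatter.

Compound 4 is therefore expected to give 7000 nM, within 2500 nM to 20000 nM.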

Compound 4, half-maximal inhibitory concentration: 3260 nM
Beside the measured number, compound 4's estimate is 2.1-fold (0.33 log units) above it; the measured number falls inside the stated range.
By their numbers in this assay, from the lowest: compounds 1 and 2 (each within the scatter of the next); then compound 4; then compound 3.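

In this assay, for the compounds shown here, bromo in place of methyl, ortho to a hydroxy group, gives a 2.8-fold lower number from compound 3 to compound 4 (0.44 log units; beyond the scatter) as the first measured step at this position and the first single-place step to lie beyond the scatter. The earlier halogen swap, a 1.6-fold higher number from compound 1 to compound 2 (0.19 log units; within the scatter) at a different place on the ring, stayed within the scatter and did not bear on this carbon, whereas this position does respond to a change of group, though modestly. Nothing available here accounts for the size or direction of the step.

Open, from the compounds shown here alone, is whether chloro, an amine or a methoxy group on this carbon would move the number further in either direction. Also open, going by these compounds, is whether the same exchange would carry over to the core of compound 1.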